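Amide nitrogen substituent change in the dihydrofuran carboxamide series

The compounds below may be only part of what the source reports. "The series", "measured", "known", "first", "only" and "open" are said of these compounds alone.

Going by the values given here, compound 2 `C=CC1=C(C(=O)NCc2ccc(Cl)cc2)C(c2ccc(F)cc2)OC1` gives 36900 nM in a functional assay on QGY7701 cells (Homo sapiens) for cytotoxicity, read by MTT assay, with a stated time of 24 h (a higher number here means a weaker inhibitor, a lower number a stronger inhibitor), and is the only member of the set with a number rather than a limit. Compound 1 `C=CC1=C(C(=O)NCc2ccccc2)C(c2ccc(OC)c(OC)c2)OC1` returns only a limit of the assay, > 100000 nM. Compound 3 `C=CC1=C(C(=O)NCc2ccc(Cl)cc2)C(c2ccc(OC)cc2)OC1` likewise returns only a limit, > 100000 nM. Among the compounds with values here, the single step that can be sized, an at least 2.7-fold higher number from compound 2 to compound 3 (0.43 log units; beyond the scatter), concerns a substituent on an aromatic carbon and not the amide-type nitrogen; it is noted with the limit of > 100000 nM in this assay, at which 2 of the 3 values shown sit, which shows how much of the series sits at that limit.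

Compound 4 `C=CC1=C(C(=O)NC2CCCCC2)C(c2ccc(F)cc2)OC1` differs from compound 2 by cyclohexyl in place of 4-chlorobenzyl on an amide-type nitrogen. Within the data shown here, no measured step touches the amide-type nitrogen, and the data leave the direction of this change open. Among the measured compounds shown here, the one sized step in the set moved toward weaker inhibition, and two of three members sit at the limit, which weighs the expectation toward a weaker number for compound 4 rather than a stronger one, with wide uncertainty. For compound 4 the expected step is a 1.6-fold higher number from compound 2 to compound 4 (0.21 log units; within the scatter). Compound 4 is therefore estimated at 60000 nM, within a range of 15000 nM to 250000 nM, with a real chance that this assay reports only a limit.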

Compound 4, half-maximal inhibitory concentration: 40500 nM
For compound 4 the middle estimate is 1.5-fold (0.17 log units) above the measured one; the range from low to high includes it.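

The amide-type nitrogen now has a step that can be read in this assay: cyclohexyl in place of 4-chlorobenzyl gives a 1.1-fold higher number from compound 2 to compound 4 (0.04 log units; within the scatter). With the fluoro substituent on the aromatic carbon held constant, this position accepts a non-aromatic carbon ring in place of a chlorinated benzyl group, and the read-out stays a number rather than a limit, with compound 2 and compound 4 level within the scatter. So neither the aromatic ring nor the chlorine of the 4-chlorobenzyl group is needed to keep a number at this level, although the series as a whole still sits close to its limit: the limit of > 100000 nM in this assay, at which 2 of the 4 values shown sit.

On these data alone, whether the amide-type nitrogen stays this tolerant with other groups, such as a short n-butyl chain, a longer n-octyl chain, or a chain ending in an amine or a carboxylic acid, remains open. Also open, as far as these compounds go, is whether cyclohexyl on this nitrogen would give a number when the fluoro substituent is replaced by methoxy, and whether any group here would give a clearly lower number than compound 2.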